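Swapping the fluorophenyl arm of a catechol compound

This account rests on a few compounds, and the source may have more. Where it says the series, first, only, none or still open, it means among the compounds named here.

Compound 1 `O=[N+]([O-])c1cc(-c2nc(-c3ccc(F)cc3)no2)cc(O)c1O`: 12.7%
Compound 2 `NC(=O)c1ccc(-c2noc(-c3cc(O)c(O)c([N+](=O)[O-])c3)n2)cc1`: 79.2%

In a functional assay on the whole organism (liver, strain NMRI) for inhibition, with Mus musculus as the target, with a stated time of 3 h, at a dose of 3 mg/kg by the oral route (on this read-out higher numbers stand for more inhibition at the one dose given (going by the name of the read-out) and lower numbers for less inhibition), compound 1 gives 12.7%, the lowest of the two numbers shown; in this assay compound 2 gives 79.2%. Within the data shown here, the only measured step, a number 66.5 percentage points higher from compound 1 to compound 2 (beyond the scatter), shows that changing the far end of the molecule can move this read-out a great deal. Compound 3 `Cc1nc(-c2noc(-c3cc(O)c(O)c([N+](=O)[O-])c3)n2)cs1` differs from compound 1 by 2-methyl-1,3-thiazol-4-yl in place of 4-fluorophenyl on an aromatic carbon. This change is not the same as the measured one, so that step is only a loose guide. A rise beyond the scatter is expected, a number 27.3 percentage points higher from compound 1 to compound 3 (beyond the scatter), with wide uncertainty. Compound 3 is estimated at 40%, between 10% and 75%.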

Compound 3, a percentage reported as inhibition, in the whole organism at one dose (the size of the read-out at that dose, not a potency): 22.9%
Compound 3: middle estimate off by 17.1 percentage points, on the high side; measured number inside the range.
By their numbers in this assay, from the lowest: compound 1; then compound 3; then compound 2.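

In this assay, replacing the whole 4-fluorophenyl ring with 2-methyl-1,3-thiazol-4-yl gives a number 10.2 percentage points higher from compound 1 to compound 3 (beyond the scatter). So a change of the ring itself can also raise the number at this position, not only a change of the group on the phenyl ring, yet compound 3 at 22.9% stays far under compound 2 at 79.2%. No measurement shown here explains these differences. Open, as far as these compounds go, is how a phenyl ring carrying an amine or a carboxylic acid in place of the fluoro would compare with compound 2.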